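Compound 3: trifluoromethyl added to compound 2

This account rests on a few compounds, and the source may have more. Where it says the series, first, only, none or still open, it means among the compounds named here.

In a toxicity assay on THP-1 cells (Homo sapiens) for cytotoxicity (on this read-out higher numbers stand for an effect only at larger amounts of compound and lower numbers for an effect already at smaller amounts), compound 1 (`Cc1n[nH]c(-c2ncc3cccnc3c2O)n1`) reads > 50100 nM as a limit of the assay, not a number. Compound 2 (`Cc1n[nH]c(-c2ncc3c(-c4ccccc4)ccnc3c2O)n1`) also reads only as a limit (> 50100 nM). Going by the values given here, the one measured step (a step that the two limits leave unreadable from compound 1 to compound 2) has no readable size, and both values sit at the same limit (the limit of > 50100 nM in this assay, at which 2 of the 2 values shown sit). Compound 3 (`Cc1n[nH]c(-c2ncc3c(-c4ccccc4C(F)(F)F)ccnc3c2O)n1`) carries one change from compound 2 (trifluoromethyl in place of hydrogen on an aromatic carbon): trifluoromethyl in place of hydrogen on an aromatic carbon, ortho to a large group. The expected step in this assay is none beyond the scatter (a number no higher from compound 2 to compound 3 (the limit leaves the size open)). For compound 3 the estimate is 50100 nM (expected range 20000 nM to 100000 nM), probably reported as a limit again.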

Compound 3, half-maximal effective concentration in the THP-1 assay: > 50100 nM
Compound 3 was reported as a limit (the forecaster's own chance of this, stated with the estimate: 80%); the middle value sits exactly at the limit.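

In the THP-1 assay compound 3 gives > 50100 nM, a limit of the assay. Going by these compounds alone, in the THP-1 assay compound 2 gives > 50100 nM, also a limit of the assay, so no step between these two compounds can be read. The compounds shown leave open where compound 1, compound 2 and compound 3 truly lie on this read-out. In a physicochemical assay for solubility, measured as kinetic solubility (a lower number here means a less soluble compound, a higher number a more soluble compound), compound 2 gives 160000 nM. In the physicochemical assay compound 3 gives > 250000 nM, a limit of the assay. In the physicochemical assay trifluoromethyl in place of hydrogen on an aromatic carbon goes with an at least 1.5-fold higher number from compound 2 to compound 3 (0.19 log units; that floor lies within the scatter).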